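Swapping chloro for trifluoromethyl on an aromatic ring

A few compounds are considered here, and "the series" means these few. Any claim that something is new, unique, unknown or untested is made for them only; others in the source may bear on it.

Measured so far:
Compound 1 `CS(=O)(=O)c1cc(Cl)ccc1NCC1=NCCN1`, in an assay for binding affinity to Alpha-1A adrenergic receptor (Homo sapiens), read by radioligand binding (on this read-out higher numbers stand for weaker inhibition and lower numbers for stronger inhibition), compound 1 gives 457 nM.
Compound 2 `CS(=O)(=O)c1ccc(Cl)cc1NCC1=NCCN1`, in this assay compound 2 gives 537 nM.

Among these two numbers compound 2 stands highest, but its gap to compound 1 lies within the scatter, so the two results cannot be told apart. Compound 3 `CS(=O)(=O)c1ccc(C(F)(F)F)cc1NCC1=NCCN1` has not been measured. It differs from compound 2 by trifluoromethyl in place of chloro on an aromatic carbon, the change sitting on an aromatic carbon of the six-membered carbon ring, para to a methylsulfonyl group. Among the compounds with values here, no measured pair shows what such a swap does here, so the expectation must rest on the two values alone. In this assay a step of a 1.3-fold higher number from compound 2 to compound 3 (0.12 log units; within the scatter) is expected, that is, no step beyond the scatter, with a lean toward a weaker result. Compound 3 is therefore estimated at 700 nM, with a range from 250 nM to 2000 nM.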

Compound 3, inhibition constant: < 12600 nM
Compound 3 was reported as a limit (the forecaster's own chance of this, stated with the estimate: 5%); the middle value lies beyond the limit too.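

In this assay compound 3 gives < 12600 nM as a limit and not a number. Within the data shown here, no step from compound 2 to compound 3 can be read. The compounds shown leave open whether trifluoromethyl in place of chloro on an aromatic carbon changes the result in this assay at all, and in which direction.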